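The source may hold more compounds than are shown below. What is called first, only, known or untested is meant among the compounds shown, and "the series" means these compounds.

Measured in a functional assay on A-375 cells (Homo sapiens) for antiproliferative activity, read by CCK-8 assay, with a stated time of 72 h, tested at 8 uM; a lower number here means a weaker effect, a higher number a stronger effect of the compound at the concentration tested:

Compound 1 `Nc1ccccc1NC(=O)c1ccc(CSC(=S)N2CCc3ccccc32)cc1` gives 85.4%.
Compound 2 `Nc1ccccc1NC(=O)c1ccc(CSC(=S)N2CCCc3ccccc32)cc1` gives 81.5%.
Compound 3 `CC1CCCCN1C(=S)SCc1ccc(C(=O)Nc2ccccc2N)cc1` gives 85.2%.

Compound 3 sits second highest of these three, but its gaps to both neighbours are within the scatter: a number 0.2 percentage points lower from compound 1 to compound 3 (within the scatter) and a number 3.7 percentage points higher from compound 2 to compound 3 (within the scatter). Compound 4 `CC1CCN(C(=S)SCc2ccc(C(=O)Nc3ccccc3N)cc2)CC1` has not been tested; the change is 4-methylpiperidin-1-yl in place of 2-methylpiperidin-1-yl on a thiocarbonyl carbon. Within the data shown here, no measured step moves a group around the same ring; the three known steps exchange whole rings on the thiocarbonyl carbon and all stay within the scatter, including a number 3.9 percentage points lower from compound 1 to compound 2 (within the scatter). Compound 4 is therefore expected to show no step beyond the scatter in this assay, that is a number 1.2 percentage points lower from compound 3 to compound 4 (within the scatter). Compound 4 is estimated at 84%, between 74% and 92%.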

Compound 4, a percentage reported as inhibition, at one concentration (the size of the read-out at that concentration, not a potency): 87.4%
For compound 4 the middle estimate is 3.4 percentage points below the measured one, and the stated range covers the measured number.
By their numbers in this assay, from the lowest: compounds 2, 3, 1 and 4 (each within the scatter of the next).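

In this assay, among these compounds, this is the first change that only shifts a methyl around the same ring, 4-methylpiperidin-1-yl in place of 2-methylpiperidin-1-yl on a thiocarbonyl carbon (a number 2.2 percentage points higher from compound 3 to compound 4 (within the scatter)), so this read-out does not separate the two methyl placements. The ring exchanges that lead to compound 4 also stay small (a number 5.9 percentage points higher from compound 2 to compound 4 (within the scatter); a number 2 percentage points higher from compound 1 to compound 4 (within the scatter)), so all the rings shown here remain indistinguishable at this concentration. No measured evidence bears on why these numbers stay so close.

On these data alone, a piperidin-1-yl without the methyl, or a morpholin-4-yl, on this carbon remains open. So does how the effects of these compounds compare at other concentrations; a single concentration gives only the size of the effect at that concentration.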